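A few compounds are considered here, and "the series" means these few. Any claim that something is new, unique, unknown or untested is made for them only; others in the source may bear on it.

For the measured compounds named here, in a functional assay on HOP-92 cells (Homo sapiens) for inhibition, read by sulforhodamine B assay, with a stated time of 48 h (a higher number here means a weaker inhibitor of growth, a lower number a stronger inhibitor of growth), compound 1 (`O=C(Cc1csc2nc(-c3ccc(Br)cc3)cn12)N/N=C/c1ccccc1`) gives 12300 nM and compound 2 (`O=C(Cc1csc2nc(-c3ccc(Br)cc3)cn12)N/N=C/c1ccccc1O`) gives 2090 nM which is the lower of the two numbers measured so far. Going by the values given here, the one measured step (a 5.9-fold lower number from compound 1 to compound 2 (0.77 log units; beyond the scatter)) came with hydroxy in place of hydrogen on an aromatic carbon. Compound 3 (`O=C(Cc1csc2nc(-c3ccc(Br)cc3)cn12)N/N=C/c1ccc(O)cc1`) differs from compound 2 in one place (4-hydroxyphenyl in place of 2-hydroxyphenyl on a carbon with a double bond to nitrogen) with 4-hydroxyphenyl in place of 2-hydroxyphenyl on a carbon with a double bond to nitrogen. Among the compounds with values here, no measured step shows what a change of hydroxy position does, so the guidance is indirect. Compound 3 keeps a hydroxy, the group that separates compound 2 (2090 nM) from compound 1 (12300 nM) and a number between these two is therefore expected. A small move to a higher number is expected (a 2.3-fold higher number from compound 2 to compound 3 (0.36 log units; beyond the scatter)) in this assay for this change. The estimate for compound 3 is 4800 nM with an expected range from 1500 nM to 14000 nM at its two ends.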

Compound 3, concentration for 50% growth inhibition: 19100 nM
The estimate for compound 3 lay 4.0-fold (0.60 log units) below the measured number, and the stated range ends below it.
By their numbers in this assay, from the lowest: compound 2; then compounds 1 and 3 (each within the scatter of the next).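

In this assay, where the hydroxy sits on the phenyl ring matters: 4-hydroxyphenyl in place of 2-hydroxyphenyl gives a 9.1-fold higher number from compound 2 to compound 3 (0.96 log units; beyond the scatter) and undoes the whole gain seen earlier. A hydroxy alone therefore does not account for that gain, since a 1.6-fold higher number from compound 1 to compound 3 (0.19 log units; within the scatter) leaves compound 3 not distinguishable from the unsubstituted compound 1, and among these three compounds only the 2-hydroxyphenyl of compound 2 stands apart. Nothing available here accounts for this difference between the two hydroxyphenyl groups. The compounds shown leave open whether a methoxy or an amine in place of the hydroxy of compound 2 would keep its number. They also leave open whether a chlorine in place of the bromine on the shared core would alter the difference between compound 2 and compound 3.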